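This account rests on a few compounds, and the source may have more. Where it says the series, first, only, none or still open, it means among the compounds named here.

Compound 1, `O=C1C(Br)=C[C@H]2CO[C@@H]1O2`, and compound 2, `O=C1C[C@H](Sc2ccccc2)[C@H]2CO[C@@H]1O2`, share their core with compound 3, `CCCCS[C@H]1CC(=O)[C@@H]2OC[C@H]1O2`, and with compound 4, `CCCCCCS[C@H]1CC(=O)[C@@H]2OC[C@H]1O2`. In a functional assay on Huh-7 cells (Homo sapiens) for cytotoxicity, read by MTT assay, with a stated time of 48 h (a higher number here means a weaker inhibitor, a lower number a stronger inhibitor), compound 1 gives 4680 nM. In this assay compound 2 gives 11000 nM. Compound 3 stands apart from both: in this assay compound 3 gives "not active" (no number reported), and no number at all is attached to it, so it cannot be placed on the same scale as compound 1 or compound 2.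

The step from compound 3 to compound 4 is ethyl in place of hydrogen on a saturated chain carbon, four bonds along the chain from a sulfur. Among the measured compounds shown here, no measured pair in this set shows what lengthening a thioether chain does here, so there is no basis for expecting a shift in either direction beyond the scatter of this assay. Starting from a compound without a number, the most probable outcome is that compound 4 is likewise weak or reported without a number. Compound 4 is therefore estimated at 25000 nM, within a range from 6000 nM to 100000 nM.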

Compound 4, half-maximal inhibitory concentration: "not active" (no number reported)
For compound 4 the study gives words and no number; no gap can be computed for the estimate.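

Compound 3 and compound 4 are both reported in words without a number, so no step can be read between them. No evidence available here bears on this result. The compounds shown leave open whether the length of the thioether chain has any effect in this assay.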